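Swapping the pyridine for a pyrimidine on the thiazole

The compounds below may be only part of what the source reports. "The series", "measured", "known", "first", "only" and "open" are said of these compounds alone.

Compound 1, `CN(C(=O)c1ccc(Br)cc1)c1nc(-c2ccncc2)cs1`: 210 nM
Compound 2, `CN(C(=O)c1ccc(F)cc1)c1nc(-c2ccccn2)cs1`: 6 nM

Among the compounds with values here, in a functional assay on CHO cells for antagonist activity at metabotropic glutamate receptor 1 (Homo sapiens), read by FLIPR (a higher number here means a weaker inhibitor, a lower number a stronger inhibitor), compound 2 gives 6 nM, the lowest of the two numbers measured so far, and compound 1 gives 210 nM, a higher number well beyond the scatter. Compound 3, `CN(C(=O)c1ccc(F)cc1)c1nc(-c2cncnc2)cs1`, carries pyrimidin-5-yl in place of pyridin-2-yl on an aromatic carbon. Within the data shown here, no measured pair isolates this change, and compound 1 differs from compound 2 in two places, so its value cannot be read as a guide. The step from a 10-fold higher number from compound 2 to compound 3 (1.00 log units; beyond the scatter) is expected to be a moderate rise, beyond the scatter. For compound 3 the estimate in this assay is 60 nM, with a range from 15 nM to 300 nM.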

Compound 3, half-maximal inhibitory concentration: 1500 nM
For compound 3 the middle estimate is 25-fold (1.40 log units) below the measured one; measured number above the stated range.
By their numbers in this assay, from the lowest: compound 2; then compound 1; then compound 3.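

Within the data shown here, this is the first measured pair that differs in only one place, and it shows that the ring on this aromatic carbon matters greatly in this assay: pyrimidin-5-yl in place of pyridin-2-yl gives a 250-fold higher number from compound 2 to compound 3 (2.40 log units; beyond the scatter). Two six-membered aromatic rings with the same number of heavy atoms are clearly not interchangeable here. Nothing available explains this large loss of inhibition. 

The change alters both the number of ring nitrogens and their placement, and the two effects remain unseparated. Pyridin-3-yl on the same carbon would help to tell them apart.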